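This account rests on a few compounds, and the source may have more. Where it says the series, first, only, none or still open, it means among the compounds named here.

Working notes on the group carried through sulfur on the shared core. In an ADME assay on GES1 cells (Homo sapiens) for inhibition, read by MTT assay, with a stated time of 72 h (on this read-out lower numbers stand for stronger inhibition and higher numbers for weaker inhibition), compound 3 `COc1ccc(CSc2nc3nc(C)cc(Nc4cc(-c5ccccc5)[nH]n4)n3n2)cc1` gives 28200 nM. Compound 2 `Cc1cc(Nc2cc(-c3ccccc3)[nH]n2)n2nc(SCc3ccccc3Br)nc2n1` gives 41100 nM. The gap is a 1.5-fold lower number from compound 2 to compound 3 (0.16 log units; within the scatter), so these two compounds cannot be ordered, and compound 3 stands level with compound 2 on the numbers shown.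

Compound 1 `Cc1cc(Nc2cc(-c3ccccc3)[nH]n2)n2nc(SCC3CCCCC3)nc2n1` gives > 50000 nM, which is a limit of the assay and not a number. The two steps that start there, an at least 1.2-fold lower number from compound 1 to compound 2 (0.08 log units; that floor lies within the scatter) and an at least 1.7-fold lower number from compound 1 to compound 3 (0.24 log units; that floor lies within the scatter), are therefore floors only.

The next change leads to compound 4 `Cc1cc(Nc2cc(-c3ccccc3)[nH]n2)n2ncnc2n1`: hydrogen in place of (4-methoxybenzyl)sulfanyl on an aromatic carbon. The sulfur leaves along with the rest of the group. For the measured compounds named here, none of the measured steps removes this group, as all three only exchange the ring on the saturated chain carbon bound to the sulfur, so they bear on this change only indirectly. None of them shows a clear effect, and a large step is not expected in this assay. Judging from an at least 1.7-fold lower number from compound 1 to compound 3 (0.24 log units; that floor lies within the scatter), a modest move towards a higher number is expected, and the result may turn out to be only a limit.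

The expected size of the change is a 1.8-fold higher number from compound 3 to compound 4 (0.25 log units; within the scatter). Compound 4 is estimated at 50000 nM, with an expected range of 20000 nM to 120000 nM.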

Compound 4, half-maximal inhibitory concentration: > 50000 nM
Compound 4: a limit, no number; the forecaster's own chance of this, stated with the estimate: 55%; the middle value sits exactly at the limit.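

In this assay compound 4 gives > 50000 nM, which is a limit of the assay and not a number. For the compounds shown here, this is the first change that takes the whole (4-methoxybenzyl)sulfanyl or (2-bromobenzyl)sulfanyl group off the aromatic carbon rather than exchanging only its ring, yet it yields only floors, an at least 1.7-fold higher number from compound 3 to compound 4 (0.24 log units; that floor lies within the scatter) and an at least 1.2-fold higher number from compound 2 to compound 4 (0.08 log units; that floor lies within the scatter), so the data do not show that the group at this position moves the read-out. The step from compound 1 to compound 4 cannot be read, and the loss of all 10 heavy atoms therefore cannot be set against the (cyclohexylmethyl)sulfanyl group, because both compounds stand at the same limit: the limit of > 50000 nM in this assay, at which 2 of the 4 values shown sit.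

Still open, from the compounds shown here alone, is where compound 1 and compound 4 would fall beyond that limit, and so whether any group on this aromatic carbon gives a clear change from hydrogen in this assay. Going by these compounds, how an amine, or a shorter chain such as methylsulfanyl, would read at this position also remains open.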